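The compounds below may be only part of what the source reports. "The series", "measured", "known", "first", "only" and "open" are said of these compounds alone.

Compound 1 `COc1cc(-c2ccnc3cc(-c4ccc(F)cc4)nn23)cc(OC)c1OC` gives 4540 nM in a functional assay on B16-F0 cells (Mus musculus) for inhibition, read by CCK-8 assay, with a stated time of 48 h (on this read-out higher numbers stand for weaker inhibition and lower numbers for stronger inhibition), compound 3 `COc1cc(-c2ccnc3cc(-c4cn(C(=O)OC(C)(C)C)c5ccccc45)nn23)cc(OC)c1OC` gives 3070 nM, and compound 2 `C=Cc1ccc(-c2cc3nccc(-c4cc(OC)c(OC)c(OC)c4)n3n2)cc1` gives 788 nM, the lowest of the three numbers. Compound 4 `COc1cc(-c2ccnc3cc(-c4ccc(C(C)(C)C)cc4)nn23)cc(OC)c1OC` differs from compound 2 in one place: tert-butyl in place of vinyl on an aromatic carbon. Going by the values given here, the only measured step at this carbon is a 5.8-fold lower number from compound 1 to compound 2 (0.76 log units; beyond the scatter); no step from vinyl to tert-butyl has been measured, and compound 3 carries a different group altogether. Because a 5.8-fold lower number from compound 1 to compound 2 (0.76 log units; beyond the scatter) shows that the group on this carbon can move the number well beyond the scatter, while tert-butyl is neither fluoro nor vinyl, the direction is uncertain. Compound 4 is expected to show a 1.5-fold higher number from compound 2 to compound 4 (0.18 log units; within the scatter). The value of compound 4 is estimated at 1200 nM, ranging from 400 nM to 4000 nM.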

Compound 4, half-maximal inhibitory concentration: > 10000 nM
Compound 4: a limit, no number (the forecaster's own chance of this, stated with the estimate: 3%); middle value at least 8.3-fold (0.92 log units) away from the limit.
By their numbers in this assay, from the lowest: compound 2; then compounds 3 and 1 (each within the scatter of the next). At a limit, above all of these: compound 4.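

For compound 4 the read-out in this assay is a limit and not a number: the limit of > 10000 nM in this assay, at which 1 of the 4 values shown sits. The group on this aromatic carbon can therefore move the number in both directions, as tert-butyl in place of vinyl gives an at least 12-fold higher number from compound 2 to compound 4 (1.10 log units; beyond the scatter), and tert-butyl in place of fluoro gives an at least 2.2-fold higher number from compound 1 to compound 4 (0.34 log units; beyond the scatter). Of the three groups at this carbon, vinyl gives the lowest number and tert-butyl the highest, with fluoro in between. The compounds shown leave open whether the double bond of vinyl matters, which an ethyl group would address, and how an amine at this carbon would compare.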